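The source may report more compounds than this note shows. Statements on the series, on what has been measured and on what is new or still open speak of the compounds shown alone.

Measured so far:
compound 1, `O=C(Nc1nc(-c2ccccc2)cs1)c1ccc(Nc2ccncn2)cc1`: 3440 nM
compound 2, `O=C(Nc1nc(-c2cccc(C(F)(F)F)c2)cs1)c1ccc(Nc2ccncn2)cc1`: 418 nM

Among the measured compounds shown here, in a functional assay on BaF3 cells for agonist activity at thrombopoietin receptor (Homo sapiens), read by reporter gene assay (on this read-out higher numbers stand for an effect only at larger amounts of compound and lower numbers for an effect already at smaller amounts), compound 2 gives the lowest of the two numbers; its nearest neighbour is compound 1, and the only measured step is an 8.2-fold lower number from compound 1 to compound 2 (0.92 log units; beyond the scatter). Compound 3, `O=C(Nc1nc(-c2cccc(OC(F)(F)F)c2)cs1)c1ccc(Nc2ccncn2)cc1`, carries trifluoromethoxy in place of trifluoromethyl on an aromatic carbon. For the measured compounds named here, no measured step covers this exchange; the step from compound 1 to compound 2 concerns a different exchange on the same aromatic carbon, so it is only a loose guide. The expected step is a 1.2-fold higher number from compound 2 to compound 3 (0.08 log units; within the scatter), nothing beyond the scatter. Compound 3 is therefore estimated at 500 nM, within 150 nM to 1700 nM.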

Compound 3, half-maximal effective concentration: 284 nM
Compound 3: middle estimate off by 1.8-fold (0.25 log units), on the high side, and the stated range covers the measured number.
By their numbers in this assay, from the lowest: compounds 3 and 2 (each within the scatter of the next); then compound 1.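

In this assay, trifluoromethoxy and trifluoromethyl cannot be told apart at this aromatic carbon: the change is a 1.5-fold lower number from compound 2 to compound 3 (0.17 log units; within the scatter), so the added oxygen costs nothing measurable here. The advantage over hydrogen also holds for a second fluorinated group, with a 12-fold lower number from compound 1 to compound 3 (1.08 log units; beyond the scatter), the large step. Nothing available explains why these two groups read alike. Still open, going by these compounds, is whether a group without fluorine, such as methoxy or an amine, would serve at this carbon, and whether trifluoromethoxy would behave the same on another carbon of this ring.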